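This account rests on a few compounds, and the source may have more. Where it says the series, first, only, none or still open, it means among the compounds named here.

Compound 1 `Cc1ccc(/C=C2\CN(C(=O)CCSCCO)C/C(=C\c3ccc(C)cc3)C2=O)cc1` and compound 2 `Cc1ccc(/C=C2\CN(C(=O)CCSCCS(=O)(=O)O)C/C(=C\c3ccc(C)cc3)C2=O)cc1` share one core and differ only at the far end of the short chain attached to the amide. In a functional assay on HSC-4 cells (Homo sapiens) for cytotoxicity, read by MTT assay, with a stated time of 48 h (on this read-out lower numbers stand for higher toxicity in this test and higher numbers for lower toxicity in this test), compound 1 gives 1560 nM, while compound 2 gives 126000 nM. The change from compound 2 to compound 1 is hydroxy in place of sulfo on a saturated chain carbon, two bonds along the chain from a sulfur, and it produced an 81-fold lower number from compound 2 to compound 1 (1.91 log units; beyond the scatter).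

Compound 3 `COc1ccc(/C=C2\CN(C(=O)CCSCCS(=O)(=O)O)C/C(=C\c3ccc(OC)cc3)C2=O)cc1` carries the same sulfo-ended chain on another core; how the core of compound 3 differs from the core of compound 2 is not broken down here. In this assay compound 3 gives 91700 nM, a number that sits close to that of compound 2, within the usual scatter.

Compound 4 `COc1ccc(/C=C2\CN(C(=O)CCSCCO)C/C(=C\c3ccc(OC)cc3)C2=O)cc1` is what results when the same kind of change is applied to compound 3: hydroxy in place of sulfo on a saturated chain carbon, two bonds along the chain from a sulfur. The place of the change is described in the same words for both pairs, so the two changes are of the same kind at the same kind of position.

Because the change from compound 2 to compound 1 gave an 81-fold lower number from compound 2 to compound 1 (1.91 log units; beyond the scatter), and because compound 3 starts from 91700 nM, the expected step for compound 4 is of similar size, a 76-fold lower number from compound 3 to compound 4 (1.88 log units; beyond the scatter). The expected value for compound 4 is about 1200 nM, estimated to fall between 400 nM and 4000 nM. This expectation rests on a single measured pair.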

Compound 4, half-maximal cytotoxic concentration: 2670 nM
The estimate for compound 4 lay 2.2-fold (0.35 log units) below the measured number; the range from low to high includes it.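

Repeated on a second core, the swap of sulfo for hydroxy on a saturated chain carbon, two bonds along the chain from a sulfur, gave in this assay a 34-fold lower number from compound 3 to compound 4 (1.54 log units; beyond the scatter), again a large step in the same direction. Set side by side, the two steps cannot be told apart: the same change on two cores in this assay, an 81-fold lower number (1.91 log units; beyond the scatter) from compound 2 to compound 1 and a 34-fold lower number (1.54 log units; beyond the scatter) from compound 3 to compound 4, 2.4-fold (0.37 log units) apart, within the scatter of two such steps. So on these two cores the change carries over, with the hydroxy compound giving the much lower number each time and therefore the higher toxicity in this test, but two pairs do not show that it would hold on a third core, and they do not explain why the swap has so large an effect.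

The compounds shown leave open whether the large step belongs to sulfo and hydroxy alone or would also appear with other groups in the same place, such as a carboxylic acid or an amine, and whether it would survive on a longer chain. They also leave open how these pairs would behave on cells other than the single cell type tested here, so the result so far applies only to this one test.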